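The compounds below may be only part of what the source reports. "The series", "measured", "known", "first", "only" and "open" are said of these compounds alone.

Measured so far in an in vitro functional assay on RBL cells for antagonist activity at C-C chemokine receptor type 8 (Homo sapiens), read by FLIPR and calcium flux; a lower number here means a stronger inhibitor, a higher number a weaker inhibitor:
Compound 1 `COc1ccc2nccc(C3CN(C4CCN(Cc5cc6ccccc6[nH]5)CC4)C(=O)O3)c2c1` gives 25.1 nM.
Compound 2 `COc1ccc2nccc(C3CN(CC4CCCN(Cc5cc6ccccc6[nH]5)C4)C(=O)O3)c2c1` gives only a limit of this assay, < 50200 nM.
Compound 3 `O=C1OC(c2ccnc3ccccc23)CN1C1CCN(Cc2cc3ccccc3[nH]2)CC1` gives 1000 nM.

Among the two numbers, compound 1 stands lowest; its nearest neighbour is compound 3, reached by a 40-fold higher number from compound 1 to compound 3 (1.60 log units; beyond the scatter). Compound 4 `CCCCCCN1CCC(N2CC(c3ccnc4ccc(OC)cc34)OC2=O)CC1` differs from compound 1 by pentyl in place of 1H-indol-2-yl on a saturated chain carbon bound to an amine nitrogen in a ring. For the measured compounds named here, no measured step concerns this change: the one step that has been measured, a 40-fold higher number from compound 1 to compound 3 (1.60 log units; beyond the scatter), alters the methoxy and leaves the (1H-indol-2-yl)methyl untouched, so it gives no direct guidance. With the indole removed and a hexyl chain in its place, the expectation for compound 4 is a weaker inhibitor, with a step of about a 12-fold higher number from compound 1 to compound 4 (1.08 log units; beyond the scatter). Compound 4 is therefore estimated at 300 nM, within a range of 50 nM to 3000 nM.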

Compound 4, half-maximal inhibitory concentration: 501 nM
Compound 4: middle estimate off by 1.7-fold (0.22 log units), on the low side; the measured number falls inside the stated range.
By their numbers in this assay, from the lowest: compound 1; then compounds 4 and 3 (each within the scatter of the next).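

At this position, on a saturated chain carbon bound to an amine nitrogen in a ring, replacing (1H-indol-2-yl)methyl with hexyl in this assay gives a 20-fold higher number from compound 1 to compound 4 (1.30 log units; beyond the scatter) and so shows that this group strongly affects the read-out. Even so, a chain with no ring still gives a measured value, while the indole-bearing compound 1 keeps the lower number. Nothing shown gives a cause for this step.

The change removes the rings and the hydrogen-bond donor together, leaving their separate contributions open. As far as these compounds go, whether a phenyl ring or a longer chain here would lower the number also remains open.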